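The compounds below may be only part of what the source reports. "The series", "measured", "known", "first", "only" and "open" are said of these compounds alone.

Working notes on the ester series. All four compounds share one core and an ester; they differ only in the group on a carbonyl carbon. Compound 1 `COCC(=O)OCCc1c(-c2ccccc2Cl)c2cc(Cl)ccc2[nH]c1=O` carries a methoxymethyl group there, compound 2 `O=C(OCCc1c(-c2ccccc2Cl)c2cc(Cl)ccc2[nH]c1=O)c1ccccc1` a phenyl, compound 3 `O=C(OCCc1c(-c2ccccc2Cl)c2cc(Cl)ccc2[nH]c1=O)c1cccs1` a thiophen-2-yl. In an ADME assay on HepG2 2.2.15 cells (Homo sapiens) for cytotoxicity (a higher number here means that more compound is tolerated, a lower number that less compound is tolerated), compound 1 gives 74000 nM and compound 2 gives 43000 nM; the step of a 1.7-fold lower number from compound 1 to compound 2 (0.24 log units; within the scatter). For compound 3 this assay reports only a limit, > 1700000 nM. Compound 3 therefore stands apart from the other two on the numbers shown: an at least 22-fold higher number from compound 1 to compound 3 (1.36 log units; beyond the scatter) and an at least 39-fold higher number from compound 2 to compound 3 (1.59 log units; beyond the scatter), compound 3 being the single case at the limit of > 1700000 nM in this assay, at which 1 of the 3 values shown sits.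

Compound 4 `C/C=C/C(=O)OCCc1c(-c2ccccc2Cl)c2cc(Cl)ccc2[nH]c1=O` differs from compound 3 in one place: prop-1-en-1-yl in place of thiophen-2-yl on a carbonyl carbon. The two measured steps into compound 3 bear on this change, both large and both in the same direction, and the move to compound 4 goes away from the thiophen-2-yl. Going by the values given here, a step back down in this assay is therefore expected, though a group with no ring has no close precedent apart from the methoxymethyl of compound 1, so the size of the step is uncertain and a second limit remains possible. Compound 4 is expected near 250000 nM, in the range 50000 nM to 1700000 nM. That estimate amounts to an expected step of an at least 6.8-fold lower number from compound 3 to compound 4 (0.83 log units; beyond the scatter).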

Compound 4, half-maximal cytotoxic concentration: 30000 nM
Beside the measured number, compound 4's estimate is 8.3-fold (0.92 log units) above it; the measured number lies below the stated range.
By their numbers in this assay, from the lowest: compounds 4, 2 and 1 (each within the scatter of the next, the first and the last beyond it). At a limit, above all of these: compound 3.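

Leaving the thiophen-2-yl for a group with no ring gives an at least 56-fold lower number from compound 3 to compound 4 (1.75 log units; beyond the scatter), so the large gap already seen with the phenyl and the methoxymethyl now holds for a third group on this carbonyl carbon. The prop-1-en-1-yl does not separate from the phenyl, with a 1.4-fold lower number from compound 2 to compound 4 (0.16 log units; within the scatter), and it stands only modestly apart from the methoxymethyl, with a 2.5-fold lower number from compound 1 to compound 4 (0.39 log units; beyond the scatter), so the presence of a ring alone does not decide the number in this assay. The thiophen-2-yl is thus the one exception among the four groups, and compound 3 is the only compound reported as a limit: the limit of > 1700000 nM in this assay, at which 1 of the 4 values shown sits.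

As far as these compounds go, it remains open whether this exception belongs to the five-membered aromatic ring in general or to its sulfur, and how far compound 3 truly lies from the other three, as its number is a limit only. A furan ring on the same carbonyl carbon would bear on the first question, and a longer chain or a chain carrying an amine would show how far the narrow spread of compounds 1, 2 and 4 extends.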